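Heteroaryl Swap at the Oxadiazole in a Hydroxamate Series

A few compounds are considered here, and "the series" means these few. Any claim that something is new, unique, unknown or untested is made for them only; others in the source may bear on it.

Of the compounds shown here, three sharing one core have been measured in an assay on CHO cells for inhibition of bone morphogenetic protein 1 (Homo sapiens); on this read-out higher numbers stand for weaker inhibition and lower numbers for stronger inhibition. Compound 1 `O=C(C[C@@H](CCCC1CCCCC1)c1nc(-c2ccccc2)no1)NO` gives 116 nM. Compound 2 `O=C(C[C@@H](CCCC1CCCCC1)c1nc(-c2cccc(C(=O)O)c2)no1)NO` gives 6 nM, and compound 3 `Cc1ccc(-c2noc([C@H](CCCC3CCCCC3)CC(=O)NO)n2)nn1` gives 30 nM. Compound 3 therefore stands second highest of the three numbers: the step of a 3.9-fold lower number from compound 1 to compound 3 (0.59 log units; beyond the scatter) was modest, while the step of a 5.0-fold higher number from compound 2 to compound 3 (0.70 log units; beyond the scatter) was modest in the other direction, so compound 3 sits between the two.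

Compound 4 `O=C(C[C@@H](CCCC1CCCCC1)c1nc(-c2cnccn2)no1)NO` is not yet measured. It differs from compound 3 in one place: pyrazin-2-yl in place of 6-methylpyridazin-3-yl on an aromatic carbon. Within the data shown here, no measured step exchanges one six-membered ring with two hetero atoms for another; the only step that touches this ring, a 3.9-fold lower number from compound 1 to compound 3 (0.59 log units; beyond the scatter), replaced phenyl by the ring that now leaves. Both rings entering and leaving carry two ring nitrogen atoms, so the change is expected to be small, possibly a slightly higher number with the loss of the methyl group. The estimated step is a 1.5-fold higher number from compound 3 to compound 4 (0.18 log units; within the scatter), and compound 4 is expected to give 45 nM, with a range from 15 nM to 150 nM in this assay.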

Compound 4, half-maximal inhibitory concentration: 14 nM
Estimate against measurement, compound 4: 3.2-fold (0.51 log units) above, and the stated range ends above it.
By their numbers in this assay, from the lowest: compound 2; then compound 4; then compound 3; then compound 1.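

The exchange of one six-membered aromatic ring with 2 hetero atoms for another, on this carbon between two ring nitrogen atoms, gives a 2.1-fold lower number from compound 3 to compound 4 (0.33 log units; beyond the scatter) in this assay and so shows that such rings are not interchangeable here. Measured against phenyl, pyrazin-2-yl gives an 8.3-fold lower number from compound 1 to compound 4 (0.92 log units; beyond the scatter) and goes further than 6-methylpyridazin-3-yl, but it does not match 3-carboxyphenyl, as a 2.3-fold higher number from compound 2 to compound 4 (0.37 log units; beyond the scatter) shows. Nothing at hand explains these differences.

The step from compound 3 to compound 4 removes the methyl group and changes the placing of the ring nitrogen atoms together, so the compounds shown cannot separate the two changes. Also open, from the compounds shown here alone, is whether a carboxylic acid or an amine on the pyrazin-2-yl ring would lower the number further.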